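A few compounds are considered here, and "the series" means these few. Any claim that something is new, unique, unknown or untested is made for them only; others in the source may bear on it.

The compounds share the core seen in compound 1 `COc1cc(NCc2ccc(Cl)cc2)cc(OC)c1OC`. In a functional assay on HCT-116 cells (Homo sapiens) for inhibition, read by MTT assay, with a stated time of 48 h (on this read-out lower numbers stand for stronger inhibition and higher numbers for weaker inhibition), compound 1 gives only a limit of the assay, > 80000 nM, not a number. Among the measured compounds shown here, compound 2 `C#CC(=O)N(Cc1ccc(OC)c(O)c1)c1cc(OC)c(OC)c(OC)c1` is the one compound for which a number rather than a limit is available: in this assay compound 2 gives 310 nM. Compound 3 `COc1ccc(CN(C(=O)C2CC2)c2cc(OC)c(OC)c(OC)c2)cc1O` has not yet been measured. It differs from compound 2 in a single place, (cyclopropyl in place of ethynyl on a carbonyl carbon). For the measured compounds named here, no step between two measured compounds is available, so there is nothing to measure the size of this change against, and any expectation rests on the change itself. The step from compound 2 to compound 3 in this assay is expected to go toward weaker inhibition, by a 9.7-fold higher number from compound 2 to compound 3 (0.99 log units; beyond the scatter). Compound 3 is therefore estimated at 3000 nM, with a likely range from 500 nM to 20000 nM.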

Compound 3, half-maximal inhibitory concentration: 49 nM
The estimate for compound 3 lay 61-fold (1.79 log units) above the measured number; measured number outside the range, below it.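

In this assay, this place on the carbonyl carbon, whose other neighbour is the amide-type nitrogen, now has a measured step: putting cyclopropyl in place of ethynyl gives a 6.3-fold lower number from compound 2 to compound 3 (0.80 log units; beyond the scatter). The ethynyl group, with its triple bond, is therefore not required for inhibition in these cells, since compound 3 carries a three-membered carbon ring there instead and gives stronger inhibition. Nothing shown here explains why this swap strengthens inhibition.

This single pair leaves open whether the result is particular to cyclopropyl or would hold for other groups on the same carbonyl carbon. A cyclobutyl ring, a plain methyl or an amine at this place would show whether ring size, the presence of a ring or something else tracks with the read-out.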